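Ethyl to isopropyl ester on a dihydropyridine core

The compounds below may be only part of what the source reports. "The series", "measured", "known", "first", "only" and "open" are said of these compounds alone.

Measured so far:
- Compound 1, `CC1=NC(C)=C(C(=O)OCCCN2C(=O)c3ccccc3S2(=O)=O)C(c2cccc([N+](=O)[O-])c2)/C1=C(\O)OC(C)C`: 210 nM
- Compound 2, `CO/C(O)=C1\C(C)=NC(C)=C(C(=O)OCCCN2C(=O)c3ccccc3S2(=O)=O)C1c1ccccc1[N+](=O)[O-]`: 120 nM
- Compound 3, `CCO/C(O)=C1\C(C)=NC(C)=C(C(=O)OCCCN2C(=O)c3ccccc3S2(=O)=O)C1c1cccc(Cl)c1Cl`: 353 nM

These three compounds share one core and were tested in a functional assay for inhibition, with Oryctolagus cuniculus as the target; on this read-out lower numbers stand for stronger inhibition and higher numbers for weaker inhibition. Compound 3 gives 353 nM in this assay, the highest of the three numbers. Its gap to compound 1 is within the scatter of repeated measurements, so the two cannot be ranked against each other; its gap to compound 2 lies beyond the scatter. No pair of these compounds differs in only one place, so no single change can be read off from the measured values.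

Compound 4, `CC1=NC(C)=C(C(=O)OCCCN2C(=O)c3ccccc3S2(=O)=O)C(c2cccc(Cl)c2Cl)/C1=C(\O)OC(C)C`, has not been measured. It differs from compound 3 in one place: methyl in place of hydrogen on a saturated chain carbon bound to an oxygen on an unsaturated carbon and a saturated chain carbon. Among the compounds with values here, no measured pair isolates this change. The expectation rests on the spread of the three values alone. The step from compound 3 to compound 4 is expected to be small, a 1.2-fold lower number from compound 3 to compound 4 (0.07 log units; within the scatter), with no clear direction beyond the scatter. Compound 4 is therefore estimated at 300 nM in this assay, with a range from 120 nM to 750 nM.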

Compound 4, half-maximal inhibitory concentration: 157 nM
Compound 4: the middle estimate sits 1.9-fold (0.28 log units) above what was measured; the measured number falls inside the stated range.
By their numbers in this assay, from the lowest: compounds 2, 4, 1 and 3 (each within the scatter of the next, the first and the last beyond it).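

In this assay, within the data shown here, the change from ethyl to isopropyl, with everything else held fixed, gives the first single-place step that can be read here (a 2.2-fold lower number from compound 3 to compound 4 (0.35 log units; beyond the scatter)), so this saturated chain carbon bound to an oxygen does respond to one added methyl. With the isopropoxy group kept, 2,3-dichlorophenyl in place of 3-nitrophenyl on a saturated ring carbon gives a step within the scatter (a 1.3-fold lower number from compound 1 to compound 4 (0.13 log units; within the scatter)), so these two groups cannot be told apart in this pair. Nothing available bears on why the added methyl has this effect.

From the compounds shown here alone, whether the same step appears with 3-nitrophenyl in place of 2,3-dichlorophenyl remains open. So does what a tert-butyl ester or a chain ending in an amine would do at this position.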